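A few compounds are considered here, and "the series" means these few. Any claim that something is new, unique, unknown or untested is made for them only; others in the source may bear on it.

Of the compounds shown here, three have so far been measured in an assay on isolated protein for inhibition of Leucine-rich repeat serine/threonine-protein kinase 2 variant G2019S (Homo sapiens), read by TR-FRET and LanthaScreen, with stated times of 50 min and 30 min, in the presence of a further agent that is not named here; on this read-out lower numbers stand for stronger inhibition and higher numbers for weaker inhibition. Compound 1, with the structure `C[C@@H]1CCCN1c1c(C#N)c2c(N)nc(Nc3cn(C)nc3Cl)nc2n1C`, gives 21 nM in this assay. Compound 2, `C[C@@H]1CCCN1c1cc2c(N)ncnc2n1C`, gives 6390 nM in this assay, and compound 3, `Cc1cn(C)nc1Nc1cc2c(c(N)n1)c(C#N)c(N1CCC[C@H]1C)n2C`, gives 1290 nM. Compound 1 thus stands with the lowest number of the three, and its gaps to compound 3 and to compound 2 both lie beyond the usual scatter, so it is the strongest inhibitor of this small set. Within the data shown here, no single-point step between these measured compounds has been traced, so their numbers speak only for themselves.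

Compound 4, `Cc1nn(C2COC2)cc1Nc1nc(N)c2c(C#N)c(N3CCC[C@H]3C)n(C)c2n1`, has not yet been measured. It differs from compound 1 in one place: 3-methyl-1-(oxetan-3-yl)-1H-pyrazol-4-yl in place of 3-chloro-1-methyl-1H-pyrazol-4-yl on a nitrogen on an aromatic ring. Both the group that leaves and the group that enters keep a five-membered aromatic ring with 2 hetero atoms, and only what hangs on that ring changes. Among the measured compounds shown here, with no measured pair showing a change of this kind, the expectation rests on compound 1 alone, and a small step towards weaker inhibition, near the edge of the scatter, is expected as a 1.9-fold higher number from compound 1 to compound 4 (0.28 log units; within the scatter). Compound 4 is therefore expected to give about 40 nM in this assay, within a range from 10 nM to 160 nM.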

Compound 4, half-maximal inhibitory concentration: 25 nM
The estimate for compound 4 lay 1.6-fold (0.20 log units) above the measured number; measured number inside the range.
By their numbers in this assay, from the lowest: compounds 1 and 4 (each within the scatter of the next); then compound 3; then compound 2.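

In this assay, 3-methyl-1-(oxetan-3-yl)-1H-pyrazol-4-yl in place of 3-chloro-1-methyl-1H-pyrazol-4-yl gives a 1.2-fold higher number from compound 1 to compound 4 (0.08 log units; within the scatter), so compound 1 and compound 4 cannot be told apart. Among these compounds, this is the first sign that the group on this nitrogen on an aromatic ring can change substantially, losing its chlorine and gaining a four-membered ring with an oxygen, with no loss of inhibition beyond the scatter. Nothing at hand explains why the number holds steady.

Two things change at once in this step, the chlorine giving way to a methyl and the methyl on the pyrazole nitrogen giving way to the oxetane, and the compounds shown do not separate their contributions. On these data alone, whether a piperidine ring or a carboxylic acid on that pyrazole nitrogen would be accepted equally well also remains open.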